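A few compounds are considered here, and "the series" means these few. Any claim that something is new, unique, unknown or untested is made for them only; others in the source may bear on it.

Two compounds of this series have so far been run in an ADME assay on cells (Erythrocyte, Homo sapiens) for activation, read by hemolysis, with a stated time of 30 min, tested at 2.5 mM; a higher number here means a stronger effect of the compound at the concentration tested, a lower number a weaker effect. Compound 1 `N=C(N)c1ccc(-c2ccc(-c3ccc(F)cc3)o2)o1` gives 17.6%, and compound 2 `N=C(N)c1ccc(-c2ccc(-c3ccc(Cl)cc3)s2)s1` gives 14.3%; the two numbers lie within the usual scatter of each other, so neither stands apart from the other. Compound 3 `N=C(N)c1ccc(-c2ccc(-c3ccccc3)s2)s1` has not yet been measured in this assay. It differs from compound 2 by hydrogen in place of chloro on an aromatic carbon. Going by the values given here, no step between measured compounds is available to calibrate this change, so no step beyond the scatter is expected in this assay. Compound 3 is estimated at 12%, with a range of 4% to 24%. The step this estimate implies, a number 2.3 percentage points lower from compound 2 to compound 3 (within the scatter), is an expectation only.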

Compound 3, a percentage reported as activity, at one concentration (the size of the read-out at that concentration, not a potency): 15.3%
Compound 3: middle estimate off by 3.3 percentage points, on the low side; the measured number falls inside the stated range.
By their numbers in this assay, from the lowest: compounds 2, 3 and 1 (each within the scatter of the next).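

In this assay, going by these compounds alone, hydrogen in place of chloro on the aromatic carbon para to a large group gives a number 1 percentage points higher from compound 2 to compound 3 (within the scatter) and provides the first one-place step. At this position, the read-out therefore does not separate chloro from hydrogen. No available measurement bears on the reason for this result.

On these data alone, whether an amine or a carboxylic acid at this position would shift the read-out stays open. A single step also leaves open whether the same change would behave alike on the core of compound 1.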